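The source may report more compounds than this note shows. Statements on the series, on what has been measured and on what is new or still open speak of the compounds shown alone.

Compound 1 `CCCn1c(SCc2cc([N+](=O)[O-])ccc2OC)nc2cc(NC(=O)NC(C)(C)C)ccc21` is the reference point of this short series. In an assay on isolated protein for inhibition of Gonadotropin-releasing hormone receptor (Rattus norvegicus) (on this read-out lower numbers stand for stronger inhibition and higher numbers for weaker inhibition), compound 1 gives 120 nM, the lowest of the two numbers recorded so far. Among the compounds with values here, its only measured neighbour is compound 2 `CCCCCn1c(SCc2cc([N+](=O)[O-])ccc2OC)nc2cc(NC(=O)NC(C)(C)C)ccc21`, which in this assay gives 880 nM; the step of a 7.3-fold higher number from compound 1 to compound 2 (0.87 log units; beyond the scatter) comes from ethyl in place of hydrogen on a saturated chain carbon, three bonds along the chain from an aromatic nitrogen.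

Compound 3 `CCCn1c(SCc2cc([N+](=O)[O-])ccc2OC)nc2cc(NC(=O)NC(C)(C)C)cc(C(=O)NCc3ccncc3)c21` keeps the propyl chain of compound 1 and differs from it by ((pyridin-4-yl)methyl)carbamoyl in place of hydrogen on an aromatic carbon. Within the data shown here, no measured step touches this position: the one step on record changes the chain on the aromatic nitrogen, not the carbon-only ring of the core, so it offers no direct guide to the size or direction of the change from compound 1 to compound 3. Among the measured compounds shown here, with no comparable step available, the expectation is that compound 3 stays near compound 1, and the estimated step is a 1.3-fold higher number from compound 1 to compound 3 (0.10 log units; within the scatter), carrying a wide range in both directions. Compound 3 is therefore expected to give about 150 nM, with a range from 30 nM to 800 nM.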

Compound 3, half-maximal inhibitory concentration: 35 nM
The estimate for compound 3 lay 4.3-fold (0.63 log units) above the measured number; the range from low to high includes it.
By their numbers in this assay, from the lowest: compound 3; then compound 1; then compound 2.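

The aromatic carbon ortho to a fused ring and meta to the ((tert-butyl)carbamoyl)amino group tolerates a much larger substituent than hydrogen: in this assay the entry of ((pyridin-4-yl)methyl)carbamoyl gives a 3.4-fold lower number from compound 1 to compound 3 (0.54 log units; beyond the scatter). Within the data shown here, the only earlier step, a 7.3-fold higher number from compound 1 to compound 2 (0.87 log units; beyond the scatter), changed the chain on the aromatic nitrogen and raised the number, so this is the first change to lower it, and it does so at a different place on the shared core with 10 heavy atoms entering. Nothing available here explains why the number falls with this change.

Going by these compounds, it remains open which part of the entering group carries the step, and whether a plain benzylcarbamoyl group, an unsubstituted carboxamide or a carboxylic acid on the same carbon would lower the number in the same way. Also open, on these data alone, are whether moving the ring nitrogen, as in a pyridin-3-yl analogue, alters the result, and whether the step would hold on the longer chain of compound 2.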